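The source may report more compounds than this note shows. Statements on the series, on what has been measured and on what is new or still open speak of the compounds shown alone.

In a functional assay on HCT-116 cells (Homo sapiens) for antiproliferative activity, read by sulforhodamine B assay, with a stated time of 72 h (on this read-out higher numbers stand for weaker inhibition and lower numbers for stronger inhibition), compound 1 `CCOC(=O)c1cnc2ccc(-c3cnc(OC)c(NS(=O)(=O)c4ccc(F)cc4F)c3)cn12` gives 90 nM and compound 2 `COc1ncc(-c2ccc3ncc(C(=O)N4CCC(OC(=O)c5ccccc5)CC4)n3c2)cc1NS(=O)(=O)c1ccc(F)cc1F` gives 1230 nM, so compound 1 holds the lower of the two numbers, a gap beyond the usual scatter. Compound 3 `CCCCS(=O)(=O)Nc1cc(-c2ccc3ncc(C(=O)OCC)n3c2)cnc1OC` keeps the core of compound 1 and changes one group: butyl in place of 2,4-difluorophenyl on a sulfonyl sulfur. Within the data shown here, no measured pair shows this change, so the expectation is only a judgement: a moderate move towards weaker inhibition. The expected step is a 5.0-fold higher number from compound 1 to compound 3 (0.70 log units; beyond the scatter). In this assay the estimate for compound 3 is 450 nM, with an expected range from 110 nM to 2000 nM.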

Compound 3, half-maximal inhibitory concentration: 4940 nM
The estimate for compound 3 lay 11-fold (1.04 log units) below the measured number; the measured number lies above the stated range.
By their numbers in this assay, from the lowest: compound 1; then compound 2; then compound 3.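

Putting butyl in place of 2,4-difluorophenyl on a sulfonyl sulfur weakens inhibition sharply in this assay, with a 55-fold higher number from compound 1 to compound 3 (1.74 log units; beyond the scatter). This is the first single change shown at this position, and its size shows that activity here depends strongly on the group the sulfonyl sulfur carries. No measurement shown accounts for the loss.

Still open, from the compounds shown here alone, is whether the loss follows from removing the aromatic ring or the two fluorine atoms. Plain phenyl on the sulfonyl sulfur would help separate the two, while a longer chain would test whether chain length matters.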